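A few compounds are considered here, and "the series" means these few. Any claim that something is new, unique, unknown or untested is made for them only; others in the source may bear on it.

Measured compounds in an assay for binding affinity to dual specificity mitogen-activated protein kinase kinase 4 (Homo sapiens), read by KINOMEscan, tested at 100 nM; on this read-out higher numbers stand for a weaker effect at the one concentration tested and lower numbers for a stronger effect:
compound 1 `CCCS(=O)(=O)Nc1ccc(F)c(C(=O)c2n[nH]c3ncc(-c4cccc(C)c4)cc23)c1F`, 15%;
compound 2 `CCCS(=O)(=O)Nc1ccc(F)c(C(=O)c2n[nH]c3ncc(-c4ccc(N)cc4)cc23)c1F`, 0.1%;
compound 3 `CCCS(=O)(=O)Nc1ccc(F)c(C(=O)c2n[nH]c3ncc(-c4ccc(F)cc4C)cc23)c1F`, 14%.

Compound 3 stands second highest of the three; its nearest neighbour is compound 1, with a number 1 percentage points lower from compound 1 to compound 3 (within the scatter), and its furthest is compound 2, with a number 13.9 percentage points higher from compound 2 to compound 3 (beyond the scatter). Compound 4 `CCCS(=O)(=O)Nc1ccc(F)c(C(=O)c2n[nH]c3ncc(-c4ccc(S(N)(=O)=O)cc4C)cc23)c1F` differs from compound 3 by sulfamoyl in place of fluoro on an aromatic carbon, the change reading one bond further out as 4-fluoro-2-methylphenyl to 2-methyl-4-sulfamoylphenyl. Among the compounds with values here, no measured step carries this exact change. The bearing steps are a number 14.9 percentage points lower from compound 1 to compound 2 (beyond the scatter) and a number 13.9 percentage points higher from compound 2 to compound 3 (beyond the scatter), which show that a polar hydrogen-bond-donor group on the pendant ring, as in compound 2, goes with a lower number. A step downward beyond the scatter is therefore expected, a number 9 percentage points lower from compound 3 to compound 4 (within the scatter), and compound 4 is estimated at 5%, within 0.5% to 20%.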

Compound 4, a percentage reported as activity, at one concentration (the size of the read-out at that concentration, not a potency): 3.1%
Beside the measured number, compound 4's estimate is 1.9 percentage points above it; low and high end bracket the measured number.
By their numbers in this assay, from the lowest: compounds 2 and 4 (each within the scatter of the next); then compounds 3 and 1 (each within the scatter of the next).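

In this assay, sulfamoyl in place of fluoro gives a step beyond the scatter (a number 10.9 percentage points lower from compound 3 to compound 4 (beyond the scatter)), showing that this position still responds to the change when the methyl group stays on the ring. The 2-methyl-4-sulfamoylphenyl group also separates from 3-methylphenyl (a number 11.9 percentage points lower from compound 1 to compound 4 (beyond the scatter)) but not from 4-aminophenyl (a number 3 percentage points higher from compound 2 to compound 4 (within the scatter)), so those last two groups cannot be ordered here. Nothing at hand explains these steps. Open, on these data alone, is what a carboxylic acid or a methanesulfonyl group would give at this position. Also open, as far as these compounds go, is what 4-sulfamoylphenyl, without the methyl group, would give.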